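The compounds below may be only part of what the source reports. "The series", "measured", "known", "first", "only" and "open" are said of these compounds alone.

Compound 1 `Cc1noc(C)c1S(=O)(=O)N1CCC(N2CCC(C)CC2)CC1`: > 10000 nM (a limit)
Compound 2 `COc1cc(C)ccc1S(=O)(=O)N1CCC(N2CCC(C)CC2)CC1`: > 5000 nM (a limit)
Compound 3 `CC1CCN(C2CCN(S(=O)(=O)c3ccc(OCc4ccccc4)cc3)CC2)CC1`: > 5000 nM (a limit)

All three compounds were tested in an ADME assay on HCT-116 cells (Homo sapiens) for cytotoxicity, read by CellTiter-Glo, with a stated time of 72 h (on this read-out lower numbers stand for stronger inhibition and higher numbers for weaker inhibition), and none of them gives an exact number. Compound 3 stands at > 5000 nM in this assay, which is a limit and not a measured potency. Compound 4 `CC1CCN(C2CCN(S(=O)(=O)c3ccc(C(C)(C)C)cc3)CC2)CC1` keeps the shared core of compound 3 but carries tert-butyl in place of benzyloxy on an aromatic carbon, para to a large group (tert-butyl in place of benzyloxy on an aromatic carbon). Going by the values given here, no pair of measured compounds differs in just one place, so the effect of this swap cannot be read directly from the data. Still, compounds 1, 2 and 3 carry different groups on the shared core, and all three end at limits. No change beyond the usual scatter is therefore expected, and the estimated step that the limit leaves unreadable from compound 3 to compound 4 is small. Compound 4 is expected at 7000 nM, with an estimated range of 3000 nM to 20000 nM.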

Compound 4, half-maximal inhibitory concentration: > 5000 nM
Compound 4: a limit, no number; the forecaster's own chance of this, stated with the estimate: 75%; the middle value does not contradict the limit.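

Going by these compounds alone, compound 3 and compound 4 both end at limits rather than numbers in this assay, and no step between them can be read. The compounds shown leave open how tert-butyl and benzyloxy truly compare, and whether any group on the shared core gives an exact potency.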